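A few compounds are considered here, and "the series" means these few. Any claim that something is new, unique, unknown or untested is made for them only; others in the source may bear on it.

Measured so far:
Compound 1, `C=C(C)C(=O)c1ccc(OCc2nc(C)no2)c(C)c1C`: 4000 nM
Compound 2, `C=C(C)C(=O)c1ccc(OCc2nc(-c3ccc(C(F)(F)F)cc3)no2)c(C)c1C`: 3900 nM

Both numbers come from an assay on HL-60 cells for inhibition of glutathione S-transferase P (Homo sapiens); on this read-out lower numbers stand for stronger inhibition and higher numbers for weaker inhibition. Compound 2 is nominally the lower of the two, but its gap to compound 1 lies within the scatter, so the two compounds cannot be told apart on this read-out.

The next compound, compound 3, is `C=C(C)C(=O)c1ccc(OCc2nc(-c3ccc(Cl)cc3)no2)c(C)c1C`. It differs from compound 2 in a single place: chloro in place of trifluoromethyl on an aromatic carbon. Going by the values given here, only one measured step speaks to this part of the molecule, a 1.0-fold lower number from compound 1 to compound 2 (0.01 log units; within the scatter), and it is within the scatter even though a small methyl was replaced by a whole substituted phenyl ring. That step suggests that what sits at this position of the shared core has had little bearing on the read-out so far. Among the compounds with values here, the step to compound 3 is a smaller change than that one, trading one group on the phenyl ring for another, and no measured pair tests chloro against trifluoromethyl directly. On this basis no step beyond the scatter is expected, and the estimated change is a 1.0-fold higher number from compound 2 to compound 3 (0.01 log units; within the scatter). Compound 3 is therefore expected to give about 4000 nM in this assay, within a range from 1500 nM to 10000 nM.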

Compound 3, half-maximal inhibitory concentration: 2000 nM
For compound 3 the middle estimate is 2.0-fold (0.30 log units) above the measured one; low and high end bracket the measured number.
By their numbers in this assay, from the lowest: compounds 3, 2 and 1 (each within the scatter of the next).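

Replacing trifluoromethyl with chloro, para to a large group on the phenyl ring, gives a 2.0-fold lower number from compound 2 to compound 3 (0.29 log units; within the scatter) in this assay and so shows that this exchange on the ring itself does not separate the two compounds. Set against the small methyl, the whole 4-chlorophenyl group gives a 2.0-fold lower number from compound 1 to compound 3 (0.30 log units; within the scatter) and so, like 4-(trifluoromethyl)phenyl, cannot be told apart from methyl on this read-out. Methyl, 4-(trifluoromethyl)phenyl and 4-chlorophenyl thus all lie within the scatter of one another, and nothing available here offers an explanation for this result.

Still open is whether any group at this position can move the number beyond the scatter, as the three compounds shown cover only methyl and two para-substituted phenyl rings. An amine or a carboxylic acid in place of the chloro, or a longer chain in place of the whole phenyl ring, would show whether this position really has so little bearing on the read-out.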